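Methoxy additions on a chalcone-pyrazole series in cytotoxicity

The compounds below may be only part of what the source reports. "The series", "measured", "known", "first", "only" and "open" are said of these compounds alone.

Measured compounds:
compound 1 `COc1ccc(-c2cc(/C=C/C(=O)c3cc(OC)c(OC)c(OC)c3)[nH]n2)cc1OC`, -81%
compound 2 `COc1ccc(C(=O)/C=C/c2cc(-c3cc(OC)c(OC)c(OC)c3)n[nH]2)cc1`, -64%
compound 3 `COc1ccc(C(=O)/C=C/c2cc(-c3cc(OC)c(OC)c(OC)c3)n[nH]2)cc1OC`, -76%

In a functional assay on MCF7 cells (Homo sapiens) for cytotoxicity, read by sulforhodamine B assay, with a stated time of 48 h, tested at 10 uM (on this read-out higher numbers stand for a weaker effect at the one concentration tested and lower numbers for a stronger effect), compound 3 gives -76%, the second highest of the three numbers. Compound 1 gives -81%, which lies within the scatter of compound 3. For the measured compounds named here, compound 2 gives -64%, and the step of a number 12 percentage points lower from compound 2 to compound 3 (beyond the scatter) is the only one-place change measured so far.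

Compound 4 `COc1cc(C(=O)/C=C/c2cc(-c3cc(OC)c(OC)c(OC)c3)n[nH]2)cc(OC)c1OC` is not yet measured. It differs from compound 3 by methoxy in place of hydrogen on an aromatic carbon. The step that bears on it is the earlier methoxy addition on the same ring, a number 12 percentage points lower from compound 2 to compound 3 (beyond the scatter), which was modest and beyond the scatter. Going by the values given here, a further methoxy may add a change of similar or smaller size in the same direction, but only one such step is available, so the expectation is weak.

For compound 4 the estimated step is a number 4 percentage points lower from compound 3 to compound 4 (within the scatter). Compound 4 is thus expected to give about -80%, within a range of -92% to -66%.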

Compound 4, a percentage reported as activity, at one concentration (the size of the read-out at that concentration, not a potency): -85%
Estimate against measurement, compound 4: 5 percentage points above; the measured number falls inside the stated range.
By their numbers in this assay, from the lowest: compounds 4, 1 and 3 (each within the scatter of the next); then compound 2.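

In this assay, the further methoxy, ortho to a methoxy group and meta to a large group, gives a number 9 percentage points lower from compound 3 to compound 4 (within the scatter), so here the addition cannot be told apart from the scatter, whereas the earlier addition gave a number 12 percentage points lower from compound 2 to compound 3 (beyond the scatter). The same change read from the other parent gives a number 4 percentage points lower from compound 1 to compound 4 (within the scatter), which also does not separate the pair. The two steps that can be compared across cores do not differ beyond what repeated measurements allow: the same change on two cores in this assay, a number 12 percentage points lower (beyond the scatter) from compound 2 to compound 3 and a number 4 percentage points lower (within the scatter) from compound 1 to compound 4, 8 percentage points apart, within the scatter of two such steps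

From the compounds shown here alone, whether this position accepts anything other than methoxy stays open, for instance an amine, a carboxylic acid or a longer chain such as ethoxy. Going by these compounds, a read-out at one concentration gives no potency, so any real difference among compound 1, compound 3 and compound 4 also stays open.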